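The source may report more compounds than this note shows. Statements on the series, on what has been measured and on what is new or still open speak of the compounds shown alone.

In an ADME assay (liver) for metabolic stability, with Liver microsome (Homo sapiens) as the target, read by LC-MS, using microsomes and NADPH, with a stated time of 5 min, at 37 degrees C (on this read-out lower numbers stand for slow clearance and higher numbers for fast clearance), compound 1 `CCn1c([C@@H](C)NS(=O)(=O)c2ccc(Cl)cc2)nc2ccc(OC)cc21` gives > 100 mL.min-1.g-1, which is a limit of the assay the limit of > 100 mL.min-1.g-1 in this assay, at which 1 of the 2 values shown sits, and not a number. Compound 2 `CCn1c([C@@H](C)NS(=O)(=O)C2CC2)nc2ccc(C(F)(F)F)cc21` in this assay gives < 3 mL.min-1.g-1, again a limit of < 3 mL.min-1.g-1 in this assay, at which 1 of the 2 values shown sits, rather than a number, so compound 2 stands at the slow-clearance end of what the assay reports. Compound 3 `CCCn1ncc(S(=O)(=O)N[C@H](C)c2nc3ccc(C(F)(F)F)cc3n2CC)c1C` is not yet measured; it differs from compound 2 by 5-methyl-1-propyl-1H-pyrazol-4-yl in place of cyclopropyl on a sulfonyl sulfur. For the measured compounds named here, no measured step connects any two compounds here. The change is expected to raise clearance beyond the usual scatter, with the step from compound 2 to compound 3 estimated at an at least 5.0-fold higher number from compound 2 to compound 3 (0.69 log units; beyond the scatter). Compound 3 is accordingly expected to give 15 mL.min-1.g-1 in this assay, within 4 mL.min-1.g-1 to 60 mL.min-1.g-1.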

Compound 3, intrinsic clearance in microsomes: > 100 mL.min-1.g-1
Compound 3 was reported as a limit; the forecaster's own chance of this, stated with the estimate: 25%; at least 6.6-fold (0.82 log units) between middle value and limit.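

In this assay, 5-methyl-1-propyl-1H-pyrazol-4-yl in place of cyclopropyl on a sulfonyl sulfur gives an at least 33-fold higher number from compound 2 to compound 3 (1.52 log units; beyond the scatter), so this one position spans the reported range. The core shared by compound 2 and compound 3 therefore does not by itself keep clearance slow. Compound 3 gives > 100 mL.min-1.g-1, a limit and not a number: the limit of > 100 mL.min-1.g-1 in this assay, at which 2 of the 3 values shown sit.

From the compounds shown here alone, the true size of the step remains open, as neither end of it is a number. Also open, going by these compounds, is whether a methyl in place of the propyl chain would bring clearance back towards compound 2.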